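This account rests on a few compounds, and the source may have more. Where it says the series, first, only, none or still open, it means among the compounds named here.

Going by the values given here, in an ADME assay on microsomes from liver (Rattus norvegicus) for metabolic stability, read by LC-MS, using NADPH, at 37 degrees C (a lower number here means that the compound disappears faster, a higher number that the compound lasts longer), compound 1 `Cc1oc(-c2ccccc2Cl)nc1CN1CCC(C(=O)NCCCN2C[C@H](C)C[C@H](C)C2)CC1` gives 0.25 h as the only exact number so far. Compound 2 `Cc1ccccc1-c1nc(CN2CCC(C(=O)NCCCN3CCCCC3)CC2)c(C)o1` is reported as > 0.5 h and this is a limit of the assay, not a number.

Compound 3 `Cc1oc(-c2c(Cl)cccc2Cl)nc1CN1CCC(C(=O)NCCCN2C[C@H](C)C[C@H](C)C2)CC1` has not yet been measured, and it differs from compound 1 in one place. The change is chloro in place of hydrogen on an aromatic carbon and in words it is chloro in place of hydrogen on an aromatic carbon, which turns 2-chlorophenyl to 2,6-dichlorophenyl.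

Among the compounds with values here, no two measured compounds differ in one place only, so the data offer no direct precedent for this change. The expected step of a 1.2-fold higher number from compound 1 to compound 3 (0.08 log units; within the scatter) in this assay is none beyond the usual scatter of repeated measurements. The half-life expected for compound 3 is 0.3 h with an estimated range from 0.15 h to 0.5 h for repeat measurements.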

Compound 3, half-life: 0.0483 h
Beside the measured number, compound 3's estimate is 6.2-fold (0.79 log units) above it; the measured number lies below the stated range.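

In this assay, going by these compounds alone, the change from 2-chlorophenyl to 2,6-dichlorophenyl gives a 5.2-fold lower number from compound 1 to compound 3 (0.71 log units; beyond the scatter), the first single change in this set whose size can be read. The step points towards faster disappearance, so this aromatic carbon of the ring is not a place where a chloro in place of hydrogen leaves the half-life untouched. Nothing shown here gives a cause for this step.

As far as these compounds go, whether a fluoro or a methoxy group at the same place would give a step of similar size stays open, as does whether the step depends on chloro itself. For compound 2, > 0.5 h is a limit of the assay and not a number.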